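Isopropyl in place of propyl on an aromatic nitrogen

The source may hold more compounds than are shown below. What is called first, only, known or untested is meant among the compounds shown, and "the series" means these compounds.

In a functional assay on A2780 cells (Homo sapiens) for cytotoxicity, read by sulforhodamine B assay, with a stated time of 72 h (a lower number here means a stronger inhibitor, a higher number a weaker inhibitor), compound 1 `O=C(NCc1ccc(S(=O)(=O)c2cc(F)cc(F)c2)cc1)N1Cc2ccncc2C1` gives 6.3 nM, and compound 2 `CCCn1cc(S(=O)(=O)c2ccc(CNC(=O)N3Cc4ccncc4C3)cc2)cn1` gives 7.3 nM. With only these two numbers available, compound 2 stands within the scatter of compound 1. Compound 3 `CC(C)n1cc(S(=O)(=O)c2ccc(CNC(=O)N3Cc4ccncc4C3)cc2)cn1` has not yet been measured. Relative to compound 2, it carries isopropyl in place of propyl on an aromatic nitrogen. Going by the values given here, only one measured step bears on this change, and it is indirect: 1-propyl-1H-pyrazol-4-yl in place of 3,5-difluorophenyl on a sulfonyl sulfur gave a 1.2-fold higher number from compound 1 to compound 2 (0.06 log units; within the scatter). Among the compounds with values here, no measured pair varies the propyl group itself, so the evidence is thin. Even so, a larger replacement at that sulfonyl sulfur left the number within the scatter, and no step beyond the scatter is expected here. The expected change is a 1.1-fold higher number from compound 2 to compound 3 (0.04 log units; within the scatter), with no firm direction. For compound 3 the estimated value is 8 nM, with an expected range of 3.5 nM to 18 nM.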

Compound 3, half-maximal inhibitory concentration: 11 nM
The estimate for compound 3 lay 1.4-fold (0.14 log units) below the measured number, and the stated range covers the measured number.
By their numbers in this assay, from the lowest: compounds 1, 2 and 3 (each within the scatter of the next).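

In this assay, going by these compounds alone, the first direct change to the group on the aromatic nitrogen, isopropyl in place of propyl, gives a 1.5-fold higher number from compound 2 to compound 3 (0.18 log units; within the scatter), so these two isomeric three-carbon groups cannot be told apart at this position. On the sulfonyl sulfur, 1-isopropyl-1H-pyrazol-4-yl in place of 3,5-difluorophenyl gives a 1.7-fold higher number from compound 1 to compound 3 (0.24 log units; within the scatter), so this pair cannot be told apart either. Nothing available bears on the reason for either step.

Going by these compounds, all three compounds lie within the scatter of one another, so it remains open whether the group on this nitrogen affects the number at all. Also open, on these data alone, is how a longer chain such as hexyl, or a chain ending in an amine or a carboxylic acid, would read at this position.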